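Butyl to phenyl on the oxygen of compound 3

A few compounds are considered here, and "the series" means these few. Any claim that something is new, unique, unknown or untested is made for them only; others in the source may bear on it.

Compound 1 `CCO/N=C/Nc1cc(Cl)cc(Cl)c1` gives 3 in a physicochemical assay for lipophilicity, measured as octanol-water partition; on this read-out higher numbers stand for higher lipophilicity and lower numbers for lower lipophilicity.
Compound 2 `C=CCOc1c(Cl)cc(N/C=N/OCC)cc1Cl` gives 4.3.
Compound 3 `C#CCc1c(Cl)cc(N/C=N/OCCCC)cc1Cl` gives 4.4.

Compound 3 and compound 2 give numbers that cannot be told apart, and both sit well above compound 1. Among the compounds with values here, the one measured step, a number 1.30 log units higher from compound 1 to compound 2 (beyond the scatter), concerns a different place and a different kind of group, so it does not speak to the change now in view. Compound 4 `C#CCc1c(Cl)cc(N/C=N/Oc2ccccc2)cc1Cl` differs from compound 3 by phenyl in place of butyl on an oxygen. Within the data shown here, no measured pair here exchanges a chain for a ring, so the expectation rests on the size of the groups alone: a step for compound 4 of no change at the digits printed from compound 3 to compound 4 (within the scatter), not beyond the scatter, is expected. Compound 4 is therefore estimated at 4.4, ranging from 3.9 to 4.9.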

Compound 4, partition coefficient: 4.4
Compound 4: the middle estimate sits on the measured number at the digits printed; the range from low to high includes it.
By their numbers in this assay, from the lowest: compound 1; then compounds 2, 3 and 4 (each within the scatter of the next).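

In this assay, phenyl in place of butyl on an oxygen gives no change at the digits printed from compound 3 to compound 4 (within the scatter) for this exchange. The earlier compounds shown here held no swap of a chain for a ring, and this pair shows that, at this position, a six-membered aromatic ring and a four-carbon chain cannot be told apart on this read-out. Nothing at hand explains why the two groups read alike.

Still open, from the compounds shown here alone, is how a longer chain, such as octyl, would read on this oxygen. Also open, going by these compounds, is whether an amine or a carboxylic acid at the end of the butyl chain would shift the number.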